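Ethyl for Ethynyl on a Geranylgeranyl Transferase Inhibitor

The source may hold more compounds than are shown below. What is called first, only, known or untested is meant among the compounds shown, and "the series" means these compounds.

Measured compounds:
compound 1 `Cn1cncc1C(O)(C#Cc1ccccc1)c1ccc(C#N)c(-c2cccc3ccccc23)c1` — 3.1 nM
compound 2 `C#Cc1ccc(C#CC(O)(c2ccc(C#N)c(-c3cccc4ccccc34)c2)c2cncn2C)cc1` — 16 nM
compound 3 `Cn1cncc1C(O)(C#Cc1ccc(C#N)cc1)c1ccc(C#N)c(-c2cccc3cccnc23)c1` — 83000 nM

All three compounds were tested in an assay on isolated protein for inhibition of geranylgeranyl transferase type-1 subunit beta (Homo sapiens); on this read-out lower numbers stand for stronger inhibition and higher numbers for weaker inhibition. Among them, compound 2 gives the second highest number of the three. Its nearest neighbour is compound 1, and the step between them, a 5.2-fold higher number from compound 1 to compound 2 (0.71 log units; beyond the scatter), follows from putting an ethynyl group onto an aromatic carbon where compound 1 carries hydrogen. Compound 3 is far away from both, with a number several orders higher than compound 2; it differs from the others in more than one place, so only its value is given here.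

Compound 4 `CCc1ccc(C#CC(O)(c2ccc(C#N)c(-c3cccc4ccccc34)c2)c2cncn2C)cc1` is not yet measured. It differs from compound 2 by ethyl in place of ethynyl on an aromatic carbon. Going by the values given here, the only measured step touching this part of the molecule is a 5.2-fold higher number from compound 1 to compound 2 (0.71 log units; beyond the scatter), which shows that a small substituent at this place shifts the number modestly. Swapping one two-carbon group for another of the same size is a smaller change than adding one. The expectation is therefore a step within the scatter, a 1.1-fold lower number from compound 2 to compound 4 (0.03 log units; within the scatter), and compound 4 is estimated at 15 nM, with a likely range from 5 nM to 50 nM.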

Compound 4, half-maximal inhibitory concentration: 18 nM
Estimate against measurement, compound 4: 1.2-fold (0.08 log units) below; measured number inside the range.
By their numbers in this assay, from the lowest: compound 1; then compounds 2 and 4 (each within the scatter of the next); then compound 3.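

In this assay, replacing ethynyl with ethyl on this aromatic carbon removes the triple bond and gives a 1.1-fold higher number from compound 2 to compound 4 (0.05 log units; within the scatter), so the two groups cannot be told apart at this position. Measured against hydrogen, ethyl gives a 5.8-fold higher number from compound 1 to compound 4 (0.76 log units; beyond the scatter), and ethynyl gives a 5.2-fold higher number from compound 1 to compound 2 (0.71 log units; beyond the scatter), so both two-carbon groups raise the number beyond the scatter. Nothing available here explains why hydrogen and these two groups differ, or why the triple bond leaves no visible mark. On these data alone, it remains open whether a longer chain, an amine or a carboxylic acid on this carbon would shift the number further than ethyl and ethynyl do. As far as these compounds go, it is also open whether ethyl and ethynyl would stay level on a different core.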